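A few compounds are considered here, and "the series" means these few. Any claim that something is new, unique, unknown or untested is made for them only; others in the source may bear on it.

Measured so far:
- compound 1, `CS/C(=N\C(=O)c1sccc1Cl)NC(=O)c1sccc1Cl`: 37000 nM
- compound 2, `CS/C(=N\C(=O)c1ccco1)NC(=O)c1ccco1`: 64800 nM

In a functional assay on K562 cells (Homo sapiens) for cytotoxicity, read by MTT assay, with a stated time of 72 h (a higher number here means a weaker inhibitor of growth, a lower number a stronger inhibitor of growth), compound 1 gives 37000 nM, the lower of the two numbers recorded; compound 2 gives 64800 nM, and the gap between compound 1 and compound 2 lies within the scatter of this assay, so the two cannot be told apart on these numbers.

Compound 3, `C[Se]/C(=N\C(=O)c1sccc1Cl)NC(=O)c1sccc1Cl`, is not yet measured. It differs from compound 1 only in this: a group of 2 heavy atoms (1 carbon, 1 selenium; no ring) in place of a group of 2 heavy atoms (1 carbon, 1 sulfur; no ring), on a carbon with a double bond to nitrogen. Going by the values given here, no measured pair shows this exchange, so there is nothing to set its size from. The expectation is a step no larger than the scatter of this assay, in no settled direction, a 1.3-fold lower number from compound 1 to compound 3 (0.12 log units; within the scatter). Compound 3 is therefore estimated at 28000 nM, with a range from 9000 nM to 90000 nM.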

Compound 3, concentration for 50% growth inhibition: 4810 nM
Estimate against measurement, compound 3: 5.8-fold (0.77 log units) above; measured number below the stated range.
By their numbers in this assay, from the lowest: compound 3; then compounds 1 and 2 (each within the scatter of the next).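

In this assay, replacing methylsulfanyl with its selenium counterpart, on a carbon with a double bond to nitrogen, brings a 7.7-fold lower number from compound 1 to compound 3 (0.89 log units; beyond the scatter) with the rest of the molecule unchanged. This position therefore responds to the atom it carries, which compound 1 and compound 2 could not show, since both hold methylsulfanyl there and differ elsewhere. Nothing available explains the size of this step or why it occurs.

From the compounds shown here alone, the finding rests on a single pair, so whether the same exchange on the core of compound 2 moves the number in the same way stays open. Also open, going by these compounds, is what a longer chain on the selenium, such as ethyl, or an amine on this carbon in place of methylsulfanyl would give.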